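The source may hold more compounds than are shown below. What is called first, only, known or untested is meant among the compounds shown, and "the series" means these compounds.

Within the data shown here, compound 1, `Nc1ccccc1NC(=O)/C=C/c1ccc(CSc2ccc(Cl)cc2)cc1`, is the weaker of the two compounds measured so far: in a functional assay on SMMC-7721 cells (Homo sapiens) for inhibition, read by CCK-8 assay, with a stated time of 72 h, tested at 8 uM (on this read-out higher numbers stand for more inhibition of growth at the one concentration tested and lower numbers for less inhibition of growth), compound 1 gives 16.5%. Compound 2, `Nc1ccccc1NC(=O)c1ccc(CSc2cccc(F)c2)cc1`, differs from it in more than one place and in this assay compound 2 gives 83%; the two values alone show a large gap, not tied to any single change. Compound 3, `Nc1ccccc1NC(=O)/C=C/c1ccc(CSc2ccc(C(F)(F)F)cn2)cc1`, is not yet measured and differs from compound 1 by 5-(trifluoromethyl)pyridin-2-yl in place of 4-chlorophenyl on a sulfur. Among the measured compounds shown here, no measured pair isolates this change, so the expected step of a number 8.5 percentage points higher from compound 1 to compound 3 (within the scatter) is small, with no confident direction beyond the scatter. For compound 3 the estimate is 25%, in the range 5% to 60%.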

Compound 3, percent growth inhibition at one concentration: 20.1%
Estimate against measurement, compound 3: 4.9 percentage points above, and the stated range covers the measured number.
By their numbers in this assay, from the lowest: compounds 1 and 3 (each within the scatter of the next); then compound 2.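

In this assay, 5-(trifluoromethyl)pyridin-2-yl in place of 4-chlorophenyl on a sulfur gives a number 3.6 percentage points higher from compound 1 to compound 3 (within the scatter), so this first isolated change at this position does not separate the two groups. The ring nitrogen and trifluoromethyl of the entering group bring no step beyond the scatter here, and no measurement at hand explains this result.

Still open, going by these compounds, is whether an amine or a carboxylic acid on this ring would give a different number. Compound 2 differs from compound 3 in more than one place, so no single change can be read from that pair.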